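The source may report more compounds than this note shows. Statements on the series, on what has been measured and on what is new or still open speak of the compounds shown alone.

Measured compounds, with growth inhibition in a functional assay on PC-3 cells (Homo sapiens) for inhibition, read by sulforhodamine B assay, with a stated time of 48 h; on this read-out higher numbers stand for weaker inhibition of growth and lower numbers for stronger inhibition of growth:
compound 1 `Brc1ccc(Cn2cc(CCCOc3cccc4cccnc34)nn2)cc1`, 8.4 ug/mL
compound 2 `Fc1ccc(Cn2cc(CCCOc3cccc4cccnc34)nn2)cc1F`, 6.6 ug/mL
compound 3 `Clc1ccc(Br)cc1Cn1cc(CCCOc2cccc3cccnc23)nn1`, 8.2 ug/mL

In this assay compound 3 sits within the scatter of both companions: a 1.0-fold lower number from compound 1 to compound 3 (0.01 log units; within the scatter) and a 1.2-fold higher number from compound 2 to compound 3 (0.09 log units; within the scatter). The step to compound 4 `c1cncc(CCCn2cc(CCCOc3cccc4cccnc34)nn2)c1` alters the group on the saturated chain carbon bound to an aromatic nitrogen: 2-(pyridin-3-yl)ethyl in place of 5-bromo-2-chlorophenyl on a saturated chain carbon bound to an aromatic nitrogen. Among the compounds with values here, every measured step so far also exchanged this group and stayed within the scatter (a 1.3-fold lower number from compound 1 to compound 2 (0.10 log units; within the scatter) as well), yet each kept a halogenated benzene ring; none tested a longer chain ending in a pyridin-3-yl group. Within the data shown here, with no direct precedent, no shift beyond the scatter is expected in either direction, while the range is kept wide for the untested kind of change. Compound 4 is therefore expected at 8.5 ug/mL (range 3 ug/mL to 25 ug/mL), an expected step of a 1.0-fold higher number from compound 3 to compound 4 (0.02 log units; within the scatter).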

Compound 4, concentration for 50% growth inhibition: 26.7 ug/mL
Estimate against measurement, compound 4: 3.1-fold (0.50 log units) below, outside the stated range (above it).
By their numbers in this assay, from the lowest: compounds 2, 3 and 1 (each within the scatter of the next); then compound 4.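

In this assay, the group on a saturated chain carbon bound to an aromatic nitrogen now proves able to change the result: with 2-(pyridin-3-yl)ethyl, growth inhibition weakens in all three steps (a 3.3-fold higher number from compound 3 to compound 4 (0.51 log units; beyond the scatter); a 4.0-fold higher number from compound 2 to compound 4 (0.61 log units; beyond the scatter); a 3.2-fold higher number from compound 1 to compound 4 (0.50 log units; beyond the scatter)). Exchanges among the halogenated benzene rings had stayed within the scatter. No measurement shown explains this loss.

This change swaps the ring and lengthens the chain at once, leaving their contributions unseparated. As far as these compounds go, a 3-phenylpropyl group or a pyridin-3-ylmethyl group would pull the two apart, and how either behaves remains open.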